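A chloro added next to the trifluoromethyl of compound 1

This account rests on a few compounds, and the source may have more. Where it says the series, first, only, none or still open, it means among the compounds named here.

Compound 1 `O=C(Nc1cccc(-n2cc(-c3ccncc3)c(-c3ccc(Cl)c(O)c3)n2)c1)Nc1cccc(C(F)(F)F)c1` is the starting point. In a functional assay on IGROV-1 cells (Homo sapiens) for inhibition, read by sulforhodamine B assay, with a stated time of 48 h (a lower number here means a stronger inhibitor of growth, a higher number a weaker inhibitor of growth), compound 1 gives only a limit, > 32500 nM, and no number. Among the compounds with values here, its one measured neighbour is compound 2 `O=C(Nc1cccc(-n2cc(-c3ccncc3)c(-c3ccc(Cl)c(O)c3)n2)c1)Nc1cc(C(F)(F)F)cc(C(F)(F)F)c1`, which in this assay gives 3550 nM; the step of an at least 9.1-fold lower number from compound 1 to compound 2 (0.96 log units; beyond the scatter) therefore rests on the limit of > 32500 nM in this assay, at which 1 of the 2 values shown sits, and reads as trifluoromethyl in place of hydrogen on an aromatic carbon. The new compound 3 `O=C(Nc1cccc(-n2cc(-c3ccncc3)c(-c3ccc(Cl)c(O)c3)n2)c1)Nc1ccc(Cl)c(C(F)(F)F)c1` differs from compound 1 by chloro in place of hydrogen on an aromatic carbon, a chloro in place of hydrogen on an aromatic carbon of the 3-(trifluoromethyl)phenyl group, giving 4-chloro-3-(trifluoromethyl)phenyl. Within the data shown here, the only bearing step is the one from compound 1 to compound 2, where adding a group to the same ring lowered the number beyond the scatter; a step of similar direction, though with a wide range, is expected here, an at least 4.6-fold lower number from compound 1 to compound 3 (0.66 log units; beyond the scatter). Compound 3 is thus estimated at 7000 nM, between 2000 nM and 32500 nM.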

Compound 3, concentration for total growth inhibition: 2220 nM
For compound 3 the middle estimate is 3.2-fold (0.50 log units) above the measured one, and the stated range covers the measured number.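

The chloro shows that the position ortho to the trifluoromethyl group also responds to substitution: in this assay the change gives an at least 14-fold lower number from compound 1 to compound 3 (1.16 log units; beyond the scatter). The earlier compounds shown here showed this only for a second trifluoromethyl group at another place on the ring, whereas here a single chlorine atom is enough, so with compound 2 and compound 3 two different additions to this ring both move the number beyond the scatter. The true size of the step stays unknown, as it rests on a limit and not on a number: the limit of > 32500 nM in this assay, at which 1 of the 3 values shown sits.

The compounds shown leave open whether a fluoro, a methoxy or an amine at this same place would act as the chloro does. They also leave open whether the chloro would lower the number on a ring that lacks the trifluoromethyl group.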